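Carbonyl aryl swap from compound 3 to compound 4

A few compounds are considered here, and "the series" means these few. Any claim that something is new, unique, unknown or untested is made for them only; others in the source may bear on it.

Working notes on three measured compounds and one awaiting measurement in a functional assay on UACC-257 cells (Homo sapiens) for cytotoxicity, read by sulforhodamine B assay, with a stated time of 48 h, tested at 0.01 uM; on this read-out lower numbers stand for a stronger effect and higher numbers for a weaker effect at the one concentration tested. Compound 1 `COc1cc(-c2cc(/C=C/C(=O)c3ccc(N)cc3)[nH]n2)cc(OC)c1OC` gives 94%. Compound 2 `COc1ccc(C(=O)/C=C/c2cc(-c3cc(OC)c(OC)c(OC)c3)n[nH]2)cc1OC` gives 85%. Compound 3 `COc1ccc(C(=O)/C=C/c2cc(-c3cc(OC)c(OC)c(OC)c3)n[nH]2)cc1` gives 97%, the highest number of the three; its nearest neighbour is compound 1, and the step of a number 12 percentage points higher from compound 2 to compound 3 (beyond the scatter) is the only gap here beyond the scatter.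

Compound 4 `COc1cc(-c2cc(/C=C/C(=O)c3ccc(F)c(F)c3)[nH]n2)cc(OC)c1OC` differs from compound 3 in one place: 3,4-difluorophenyl in place of 4-methoxyphenyl on a carbonyl carbon

For the measured compounds named here, two measured steps bear on this. The step of a number 9 percentage points lower from compound 1 to compound 2 (within the scatter) is a swap of the whole aryl group on the carbonyl carbon, the same kind of change as here, and it stays within the scatter. The step of a number 12 percentage points higher from compound 2 to compound 3 (beyond the scatter) removes a single methoxy on that aryl and shifts the number modestly. The step of a number 3 percentage points higher from compound 1 to compound 3 (within the scatter) changes one substituent on the same ring and stays within the scatter.

With a whole-aryl swap at the carbonyl carbon having moved the number only within the scatter, compound 4 is expected to give 90%, in a range from 78% to 100%. The expected step of a number 7 percentage points lower from compound 3 to compound 4 (within the scatter) is thus estimated to lie within the scatter, with no direction claimed.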

Compound 4, a percentage reported as activity, at one concentration (the size of the read-out at that concentration, not a potency): 88%
Estimate against measurement, compound 4: 2 percentage points above; the measured number falls inside the stated range.
By their numbers in this assay, from the lowest: compounds 2, 4, 1 and 3 (each within the scatter of the next, the first and the last beyond it).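

In this assay, for the compounds shown here, the 3,4-difluorophenyl group is the first aryl on the carbonyl carbon here that carries fluorine rather than methoxy or amino, and the number stays within the scatter of all three earlier compounds: a number 9 percentage points lower from compound 3 to compound 4 (within the scatter) against the 4-methoxyphenyl group, a number 3 percentage points higher from compound 2 to compound 4 (within the scatter) against the 3,4-dimethoxyphenyl group and a number 6 percentage points lower from compound 1 to compound 4 (within the scatter) against the 4-aminophenyl group. Going by these compounds alone, the swap for 4-methoxyphenyl also takes the count of hydrogen-bond acceptors on this aryl group from 1 to 0 without a step beyond the scatter, so across these four compounds the only gap beyond the scatter remains the one between compound 2 and compound 3. No measurement of any property of these groups is available to account for these numbers.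

The compounds shown leave open whether a saturated ring such as cyclohexyl in place of the aryl group, or a carboxylic acid on it, would give a number beyond the scatter of these four. Since the read-out comes from one concentration, it also leaves open how the four compounds would compare in the strength of their effect at any other concentration.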